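From 4-fluorophenyl to 4-methoxyphenyl

The compounds below may be only part of what the source reports. "The series", "measured", "known", "first", "only" and "open" are said of these compounds alone.

In a functional assay on HT-29 cells (Homo sapiens) for antiproliferative activity, read by MTT assay, with a stated time of 72 h (on this read-out lower numbers stand for stronger inhibition and higher numbers for weaker inhibition), compound 1 (`CCCCCn1ccnc1-c1cc(OC)c(OC)c(OC)c1`) gives 60100 nM as its reading, and compound 2 (`COc1cc(-c2nccn2-c2ccc(F)cc2)cc(OC)c1OC`) gives 29300 nM as the lower of the two numbers. Compound 3 (`COc1ccc(-n2ccnc2-c2cc(OC)c(OC)c(OC)c2)cc1`) carries methoxy in place of fluoro on an aromatic carbon, para to a large group. Among the measured compounds shown here, the only measured step bearing on this is modest, namely a 2.1-fold lower number from compound 1 to compound 2 (0.31 log units; beyond the scatter) with 4-fluorophenyl replacing pentyl on an aromatic nitrogen, so no shift beyond the scatter is expected. The step expected in this assay is a 1.5-fold lower number from compound 2 to compound 3 (0.17 log units; within the scatter) and lies within the scatter. Compound 3 is estimated at 20000 nM (range 5000 nM to 60000 nM).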

Compound 3, half-maximal inhibitory concentration: 13100 nM
Estimate against measurement, compound 3: 1.5-fold (0.18 log units) above; low and high end bracket the measured number.
By their numbers in this assay, from the lowest: compound 3; then compound 2; then compound 1.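

In this assay, the aromatic carbon para to a large group also moves the reading, not only the group on the aromatic nitrogen: methoxy in place of fluoro gives (a 2.2-fold lower number from compound 2 to compound 3 (0.35 log units; beyond the scatter)). Taken together with the earlier change, 4-methoxyphenyl in place of pentyl on the aromatic nitrogen gives (a 4.6-fold lower number from compound 1 to compound 3 (0.66 log units; beyond the scatter)). No evidence here accounts for either step. The compounds shown leave open how an amine, a hydroxyl or a longer alkoxy chain would read at this carbon.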